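A few compounds are considered here, and "the series" means these few. Any claim that something is new, unique, unknown or untested is made for them only; others in the source may bear on it.

Measured so far in a functional assay on LNCaP cells (Homo sapiens) for cytotoxicity, read by MTT assay, with a stated time of 72 h (on this read-out lower numbers stand for stronger inhibition and higher numbers for weaker inhibition), are two compounds
- compound 1 `CC1=C(/C=C/C(=O)/C=C/c2cccc(C(F)(F)F)c2)C(C)(C)CCC1` gives 2800 nM
- compound 2 `CC1=C(/C=C/C(=O)/C=C/c2ccccc2)C(C)(C)CCC1O` gives 5800 nM

Of these two numbers, compound 2 has the higher (5800 nM), so it is the weaker of the pair, and the gap to compound 1 (2800 nM) lies just beyond the scatter.

The next step leads to compound 3 `CC1=C(/C=C/C(=O)/C=C/c2cccc(C(F)(F)F)c2)C(C)(C)CCC1O` which has trifluoromethyl in place of hydrogen on an aromatic carbon of a six-membered aromatic ring of carbon only, meta to a large group. For the measured compounds named here, no pair of measured compounds isolates this change, so there is no direct precedent for its size. Going by the values given here, the only guide is compound 1, which also bears trifluoromethyl and gives 2800 nM in this assay as its number. A modest move toward a lower number is therefore expected, but this rests on one compound and remains weak evidence. The expected step is a 1.7-fold lower number from compound 2 to compound 3 (0.22 log units; within the scatter) and it is estimated to stay within the scatter. For compound 3 the estimated value is 3500 nM with an expected range from 1300 nM to 9000 nM in this measurement.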

Compound 3, half-maximal inhibitory concentration: 740 nM
Estimate against measurement, compound 3: 4.7-fold (0.67 log units) above; measured number below the stated range.
By their numbers in this assay, from the lowest: compound 3; then compound 1; then compound 2.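

In this assay, for the compounds shown here, trifluoromethyl in place of hydrogen on an aromatic carbon, meta to a large group, gives a 7.8-fold lower number from compound 2 to compound 3 (0.89 log units; beyond the scatter) and so provides the first direct reading of this change, with the hydroxy group present on the saturated ring. Read the other way, with trifluoromethyl present on the aromatic ring, hydroxy in place of hydrogen on a saturated ring carbon gives a 3.8-fold lower number from compound 1 to compound 3 (0.58 log units; beyond the scatter) and so shows that the two groups are compatible in one compound, which holds the lowest number of the three. Nothing measured here accounts for the size of either step.

From the compounds shown here alone, each step is read on a single background, so it remains open whether either would keep its size with the other group absent. Also open, going by these compounds, is whether a chlorine atom, a nitrile or a methoxy group on the same aromatic carbon would match trifluoromethyl, and whether an amine or a methyl ether on the saturated ring carbon would match the hydroxy group.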